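Flipping one ring stereocentre in a weak integrin inhibitor

A few compounds are considered here, and "the series" means these few. Any claim that something is new, unique, unknown or untested is made for them only; others in the source may bear on it.

Measured compounds:
compound 1, `CCCN(C(=O)CCCCCN)C1=C(C)CC(c2ccccc2)N(CCC(=O)O)C1=O`: > 1000000 nM
compound 2, `CCCN(C(=O)C(CC(=O)OC)C(=O)O)C1=C(C)CC(c2ccccc2)N(Cc2ccc(N)cc2)C1=O`: > 1000000 nM
compound 3, `CCCN(C(=O)CC(=O)O)C1=C(C)C[C@H](c2ccccc2)N([C@@H](C)c2ccc(N)cc2)C1=O`: 35100 nM

In an assay on K562 cells for inhibition of integrin alpha-5/beta-1 (Homo sapiens) (a higher number here means a weaker inhibitor, a lower number a stronger inhibitor), compound 1 sits at a limit of the assay, > 1000000 nM. Compound 2 likewise sits at a limit, > 1000000 nM; these two values form (the limit of > 1000000 nM in this assay, at which 2 of the 3 values shown sit). Among the measured compounds shown here, compound 3 is the only compound with a real number, 35100 nM in this assay, so it stands as the sole measured point.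

Compound 4, `CCCN(C(=O)CC(=O)O)C1=C(C)C[C@@H](c2ccccc2)N([C@@H](C)c2ccc(N)cc2)C1=O`, is its stereoisomer: the two compounds have the same atoms and bonds and differ only in configuration as drawn: 1 of 2 stereo elements differ; a stereocentre at a saturated ring carbon is drawn R in compound 3 and S in compound 4. For the measured compounds named here, no measured pair shows what such an inversion does on this core, so the step is uncertain in size and direction. Compound 4 is expected to land near compound 3 or somewhat weaker, an estimated step of a 2.0-fold higher number from compound 3 to compound 4 (0.30 log units; within the scatter), giving an estimate of 70000 nM with a range from 10000 nM to 1000000 nM in this assay.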

Compound 4, half-maximal inhibitory concentration: 57 nM
Compound 4: middle estimate off by 1200-fold (3.09 log units), on the high side; measured number outside the range, below it.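

In this assay redrawing the stereocentre at a saturated ring carbon from R to S gives a 620-fold lower number from compound 3 to compound 4 (2.79 log units; beyond the scatter) and so turns a weak inhibitor into a strong one. This large gain can be traced to that single stereocentre because nothing else separates the pair: the fact that compounds 3 and 4 differ only in the configuration as drawn. Compound 1 and compound 2 have no configuration drawn at this carbon, so they could not reveal this.

As far as these compounds go, whether the S form keeps its strength with a tetrazole in place of the carboxylic acid stays open. So does the effect of inverting the second stereocentre.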